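Swapping the oxan-4-yl tail of compound 1 for cyclopentyl

The source may hold more compounds than are shown below. What is called first, only, known or untested is meant among the compounds shown, and "the series" means these compounds.

Measured so far:
compound 1 `O=C(N[C@H]1CNC1=O)OCc1ccc(C2CCOCC2)cc1`, 1370 nM
compound 2 `CCc1ccc(CCCCOC(=O)N[C@H]2CNC2=O)cc1`, 230 nM

In an assay on HEK293 cells for inhibition of N-acylethanolamine-hydrolyzing acid amidase (Homo sapiens), read by fluorescence, with stated times of 10 min and 50 min (a lower number here means a stronger inhibitor, a higher number a weaker inhibitor), compound 1 gives 1370 nM, the highest of the two numbers; compound 2 gives 230 nM, a gap beyond the scatter. Compound 3 `O=C(N[C@H]1CNC1=O)OCc1ccc(C2CCCC2)cc1` is not yet measured. It differs from compound 1 in one place: cyclopentyl in place of oxan-4-yl on an aromatic carbon. For the measured compounds named here, no pair of measured compounds that differ in one place exists here, so the size of this step is uncertain. A modest move toward a lower number is expected, because the hydrocarbon-tailed compound 2 gives 230 nM. Compound 3 is estimated at 550 nM, within 170 nM to 1800 nM, the expected step being a 2.5-fold lower number from compound 1 to compound 3 (0.40 log units; beyond the scatter).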

Compound 3, half-maximal inhibitory concentration: 71 nM
Estimate against measurement, compound 3: 7.7-fold (0.89 log units) above, outside the stated range (below it).
By their numbers in this assay, from the lowest: compound 3; then compound 2; then compound 1.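

Cyclopentyl in place of oxan-4-yl on an aromatic carbon gives a 19-fold lower number from compound 1 to compound 3 (1.29 log units; beyond the scatter) in this assay, so the number at this position responds strongly to what the ring carries. The change alters two things at once, the ring size and the ring oxygen with its hydrogen-bond acceptor, and this single step cannot separate them. Nothing measured here explains the step. As far as these compounds go, it remains open whether cyclohexyl, which keeps the six-membered ring without the oxygen, or piperidin-4-yl, an amine in that ring, would sit nearer compound 1 or compound 3.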